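Cytotoxicity on mouse cells: cyclohexyl gives way to hex-1-yn-1-yl

The source may report more compounds than this note shows. Statements on the series, on what has been measured and on what is new or still open speak of the compounds shown alone.

Measured so far:
- Compound 1, `Cc1[nH]c2ccccc2c(=O)c1C1CCCCC1`: in an ADME assay on J774 cells (Mus musculus) for cytotoxicity (on this read-out higher numbers stand for an effect only at larger amounts of compound and lower numbers for an effect already at smaller amounts), compound 1 gives > 41400 nM.
- Compound 2, `Cc1[nH]c2ccc(F)cc2c(=O)c1Br`: in this assay compound 2 gives > 39100 nM.

Both values are limits of the assay and not numbers. Compound 1 stands at the limit of > 41400 nM in this assay, at which 1 of the 2 values shown sits. Compound 2 stands at the limit of > 39100 nM in this assay, at which 1 of the 2 values shown sits. Within the data shown here, neither compound shows a toxic effect within the amounts that were tested, and no step between two measured compounds is available, so the two values only show that both sit at the edge of what the assay can report.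

Compound 3, `CCCCC#Cc1c(C)[nH]c2ccccc2c1=O`, has not yet been measured. It differs from compound 1 in one place: hex-1-yn-1-yl in place of cyclohexyl on an aromatic carbon. The cyclohexyl and the hex-1-yn-1-yl group are counted with the same number of carbon atoms, one as a ring and one as an open chain with a triple bond.

With both measured compounds at a limit, the expected step from compound 1 to compound 3 is none beyond the scatter, an at least 1.0-fold lower number from compound 1 to compound 3 (0.01 log units; that floor lies within the scatter). Compound 3 is therefore estimated to give about 40000 nM, within a range from 12000 nM to 120000 nM, most likely again as a limit.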

Compound 3, half-maximal effective concentration: 8900 nM
Estimate against measurement, compound 3: 4.5-fold (0.65 log units) above; measured number outside the range, below it.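

Among these compounds, compound 3 is the first compound here to give a number instead of a limit in this assay, which shows that the group at this position can bring an effect on these cells within the amounts tested. Putting hex-1-yn-1-yl in place of cyclohexyl leaves the count of heavy atoms unchanged, at six carbon atoms on each side, and swaps a ring for an open chain with a triple bond; even so, the result is an at least 4.6-fold lower number from compound 1 to compound 3 (0.66 log units; beyond the scatter). That step is only a minimum, and its true size stays unknown, because the value of compound 1 is a limit: the limit of > 41400 nM in this assay, at which 1 of the 3 values shown sits.

The compounds shown leave open whether the step comes from losing the ring or from gaining the triple bond, and a plain hexyl chain at this position would tell these two apart. They also leave open how the effect on these cells depends on chain length, which a shorter but-1-yn-1-yl group or a longer oct-1-yn-1-yl group would test.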